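Adding a Fluoro to the Fused Ring of Compound 1

The source may report more compounds than this note shows. Statements on the series, on what has been measured and on what is new or still open speak of the compounds shown alone.

Compound 1 `O=c1oc2ccccc2n1Cc1ccc(Cl)cc1`: 35000 nM in an assay on HeLa cells for inhibition of Indoleamine 2,3-dioxygenase 1 (Homo sapiens), with a stated time of 24 h; a lower number here means a stronger inhibitor, a higher number a weaker inhibitor
Compound 2 `O=c1oc2ccc(Cl)cc2n1Cc1cccc(F)c1`: 9750 nM in this assay
Compound 3 `O=c1oc2ccc(F)cc2n1Cc1cccc(F)c1`: 28500 nM in this assay

Compound 1 shows the highest number of the three, close to compound 3 and well apart from compound 2. Compound 4 `O=c1oc2ccc(F)cc2n1Cc1ccc(Cl)cc1` differs from compound 1 by fluoro in place of hydrogen on an aromatic carbon. For the measured compounds named here, no measured step swaps hydrogen for fluoro at this place; the only step touching it is a 2.9-fold higher number from compound 2 to compound 3 (0.47 log units; beyond the scatter), which exchanges one halogen for another. Compounds 1 and 3 both carry fluoro in their benzyl part or on the fused ring, yet their numbers sit within the scatter of each other. Compound 4 is therefore expected to give 26000 nM, between 10000 nM and 60000 nM, a step of a 1.3-fold lower number from compound 1 to compound 4 (0.13 log units; within the scatter), not beyond the scatter.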

Compound 4, half-maximal inhibitory concentration: 80800 nM
For compound 4 the middle estimate is 3.1-fold (0.49 log units) below the measured one; the measured number lies above the stated range.
By their numbers in this assay, from the lowest: compound 2; then compounds 3 and 1 (each within the scatter of the next); then compound 4.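

Fluoro in place of hydrogen on this aromatic carbon gives, in this assay, a 2.3-fold higher number from compound 1 to compound 4 (0.36 log units; beyond the scatter), so with the rest of compound 1 unchanged, the substituted compound is the weaker inhibitor. For the compounds shown here, the earlier compounds only compared one halogen with another at this place; this step is the first to compare a halogen with hydrogen there. Nothing measured here accounts for the loss. The compounds shown leave open whether chloro at this place would also raise the number on the core of compound 1, and how a methoxy group or an amine there would compare with hydrogen.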